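Side-chain step from compound 3 to compound 4

The source may hold more compounds than are shown below. What is called first, only, known or untested is meant among the compounds shown, and "the series" means these compounds.

Measured in a functional assay on MCF7 cells (Homo sapiens) for cytotoxicity, read by MTT assay, with a stated time of 72 h; on this read-out lower numbers stand for stronger inhibition and higher numbers for weaker inhibition:
- compound 1 `COc1ncc(-c2ccc3nc(NC(=O)N4CCCC4)nn3c2)cc1NS(=O)(=O)c1ccc(F)cc1`: 1660 nM
- compound 2 `COc1ncc(-c2ccc3nc(NC(=O)NCCN4CCCCC4)nn3c2)cc1NS(=O)(=O)c1ccc(F)cc1`: 200 nM
- compound 3 `COc1ncc(-c2ccc3nc(NC(=O)NCC(=O)N4CCCC4)nn3c2)cc1NS(=O)(=O)c1ccc(F)cc1`: 2130 nM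

Compound 3 stands at the upper end of these numbers, level with compound 1: a 1.3-fold higher number from compound 1 to compound 3 (0.11 log units; within the scatter). Only compound 2 lies apart, as shown by an 8.3-fold lower number from compound 1 to compound 2 (0.92 log units; beyond the scatter) and an 11-fold higher number from compound 2 to compound 3 (1.03 log units; beyond the scatter). Compound 4 `CCCNC(=O)Nc1nc2ccc(-c3cnc(OC)c(NS(=O)(=O)c4ccc(F)cc4)c3)cn2n1` is unmeasured, and its change is ethyl in place of (pyrrolidin-1-yl)carbonyl on a saturated chain carbon bound to an amide-type nitrogen. The ethyl that enters is not the (piperidin-1-yl)methyl of compound 2, so that large step offers little support for a comparable gain. The expected step is a 1.4-fold lower number from compound 3 to compound 4 (0.15 log units; within the scatter), which means none beyond the scatter. In this assay the estimate for compound 4 is 1500 nM, with an expected range of 550 nM to 4000 nM.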

Compound 4, half-maximal inhibitory concentration: 360 nM
Compound 4: the middle estimate sits 4.2-fold (0.62 log units) above what was measured, and the stated range ends above it.
By their numbers in this assay, from the lowest: compounds 2 and 4 (each within the scatter of the next); then compounds 1 and 3 (each within the scatter of the next).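

In this assay, the ring-free propylamino on the carbonyl carbon of compound 4 reads clearly better than either pyrrolidin-1-yl (a 4.6-fold lower number from compound 1 to compound 4 (0.66 log units; beyond the scatter)) or (((pyrrolidin-1-yl)carbonyl)methyl)amino (a 5.9-fold lower number from compound 3 to compound 4 (0.77 log units; beyond the scatter)). The piperidin-1-yl of compound 2 is therefore not needed for a number in this range, since methyl in its place stays within the scatter (a 1.8-fold higher number from compound 2 to compound 4 (0.26 log units; within the scatter)). No evidence bears on what lies behind these steps. Going by these compounds, whether a longer chain such as butyl keeps this number remains open. So does the effect of a carboxylic acid or a dimethylamino group at the chain end.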